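From compound 2 to compound 3: one added methyl

This account rests on a few compounds, and the source may have more. Where it says the series, first, only, none or still open, it means among the compounds named here.

Values in hand from an ADME assay on BHK-21 cells (Mesocricetus auratus) for cytotoxicity, read by MTT assay, with a stated time of 96 h (on this read-out higher numbers stand for lower toxicity in this test and lower numbers for higher toxicity in this test), follow here
- compound 1 (`Cc1ccc(/N=N/N(C)c2ccccc2)cc1`) gives > 100000 nM as a limit of the assay
- compound 2 (`CN(C)CCCN(/N=N/c1ccccc1)c1ccccc1`) gives 50000 nM as a number

For the measured compounds named here, only these two compounds have been read so far, and they do not differ in just one place, so no measured step shows what a single change does here. Going by the values given here, compound 2 stands at 50000 nM as the only true number available. Compound 1 carries > 100000 nM and that entry is a limit of the assay, not a number.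

Compound 3 (`Cc1ccc(/N=N/N(CCCN(C)C)c2ccccc2)cc1`) departs from compound 2 in one place. The change is methyl in place of hydrogen on an aromatic carbon and it puts methyl in place of hydrogen on an aromatic carbon, so that phenyl becomes 4-methylphenyl. Among the compounds with values here, with no measured step to suggest a direction, no shift beyond the usual scatter is expected. The no change at the digits printed from compound 2 to compound 3 (within the scatter) that is expected therefore stays small. In this assay the estimate for compound 3 is 50000 nM with an expected range of 20000 nM to 100000 nM for the coming reading.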

Compound 3, half-maximal cytotoxic concentration: > 100000 nM
Compound 3 was reported as a limit (the forecaster's own chance of this, stated with the estimate: 15%); at least 2.0-fold (0.30 log units) between middle value and limit.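

In this assay the change from phenyl to 4-methylphenyl gives the first step measured at a single place in this series, an at least 2.0-fold higher number from compound 2 to compound 3 (0.30 log units; that floor lies within the scatter), so the added methyl on the aromatic carbon does not bring the reading down, although the floor of this step does not clear the scatter. Compound 3 gives > 100000 nM, which is a limit of the assay and not a number. The full size of the step therefore stays hidden, because the reading of compound 3 stops at that limit: the limit of > 100000 nM in this assay, at which 2 of the 3 values shown sit.

The step from compound 1 to compound 3 cannot be read, since both values are limits, so the compounds shown leave open what the 2-(dimethylamino)ethyl part of the chain contributes on the 4-methylphenyl series. As far as these compounds go, it also remains open whether a methoxy group, a chlorine atom or a longer alkyl chain such as ethyl in the place of this methyl would stay at the limit or give a true number in this assay.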